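The compounds below may be only part of what the source reports. "The series", "measured", "known", "first", "only" and "open" are said of these compounds alone.

Of the compounds shown here, three have been tested in a functional assay on MDA-MB-231 cells (Homo sapiens) for antiproliferative activity, read by MTT assay, with a stated time of 24 h; a higher number here means a weaker inhibitor, a lower number a stronger inhibitor. Compound 1 `Cc1ccccc1NNC(=O)c1ccc(NS(=O)(=O)c2cnc(O)nc2O)cc1` reports only a limit, > 20000 nM. Compound 2 `O=C(NNc1ccc(F)cc1)c1cccc(NS(=O)(=O)c2cnc(O)nc2O)c1`, which carries a 4-fluorophenyl group, also reports only a limit, > 20000 nM. Within the data shown here, compound 3 `O=C(NNc1ccccc1Cl)c1ccccc1NS(=O)(=O)c1cnc(O)nc1O` gives the only actual number, 18900 nM, so it stands as a weak inhibitor. Compound 4 `O=C(NNc1ccc(F)cc1)c1ccccc1NS(=O)(=O)c1cnc(O)nc1O` has 4-fluorophenyl in place of the 2-chlorophenyl of compound 3 on an amine nitrogen (4-fluorophenyl in place of 2-chlorophenyl on an amine nitrogen). Among the measured compounds shown here, no measured pair shows what this swap does, so no step beyond the usual scatter is expected in this assay. The expected step, a 1.1-fold higher number from compound 3 to compound 4 (0.05 log units; within the scatter), is therefore small. For compound 4 the estimated value is 21000 nM, with an expected range from 11000 nM to 40000 nM.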

Compound 4, half-maximal inhibitory concentration: > 20000 nM
Compound 4 gave a limit, no number; the forecaster's own chance of this, stated with the estimate: 60%; the middle value lies beyond the limit too.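

In this assay, among these compounds, putting 4-fluorophenyl in place of 2-chlorophenyl on an amine nitrogen gives an at least 1.0-fold higher number from compound 3 to compound 4 (0.02 log units; that floor lies within the scatter) as the first step that can be read at this position. Compound 4 reports a limit, so this step has a floor but no known size, and it does not separate the two compounds. Little more can be read from this series because its values gather at one point: the limit of > 20000 nM in this assay, at which 3 of the 4 values shown sit. The swap changes both the halogen and its place on the ring, and these two changes stay unseparated. A 4-chlorophenyl or an unsubstituted phenyl on the same nitrogen would bear on that question.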